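Flipping One Ring Centre in an Inactive Sugar

A few compounds are considered here, and "the series" means these few. Any claim that something is new, unique, unknown or untested is made for them only; others in the source may bear on it.

Compound 1, `CO[C@]1(CO)O[C@H](CO)[C@@H](O)[C@@H]1O`, was tested in a functional assay, with a stated time of 30 min; a lower number here means a stronger inhibitor, a higher number a weaker inhibitor. In this assay compound 1 gives > 30000 nM, which is a limit of the assay rather than a measured number. A second compound, compound 2 with structure `O=C1O[C@H]2C=C(CO)[C@@H](CO)[C@H]2[C@@H]1CO`, was tested in the same way. In this assay compound 2 gives > 30000 nM, again a limit rather than a number. Both results sit at the same boundary, as seen in the limit of > 30000 nM in this assay, at which 2 of the 2 values shown sit, so neither compound shows measurable inhibition over the concentrations covered. Compound 3, `CO[C@@]1(CO)O[C@H](CO)[C@@H](O)[C@@H]1O`, has not yet been tested. It differs from compound 1 in one respect: the two compounds have the same atoms and bonds and differ only in configuration as drawn: 1 of 4 stereo elements differ; a stereocentre at a saturated ring carbon is drawn R in compound 1 and S in compound 3. Among the measured compounds shown here, no measured pair of compounds here shows how such a change of configuration shifts potency, so the expectation rests on compound 1 alone, which sits at the limit. The step from compound 1 to compound 3 is expected to be a step that the limit leaves unreadable from compound 1 to compound 3, that is, no change beyond the usual scatter. Compound 3 is therefore expected to give 40000 nM, within a range from 15000 nM to 150000 nM, most likely reported once more as a limit.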

Compound 3, half-maximal inhibitory concentration: > 30000 nM
Compound 3 ended at the assay's limit (the forecaster's own chance of this, stated with the estimate: 85%); the middle value is on the limit's open side.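

In this assay, among the compounds shown here, compound 1 and compound 3 both sit at a limit of the assay rather than at a measured number, so no step between them can be read: the limit of > 30000 nM in this assay, at which 3 of the 3 values shown sit. The compounds shown leave open whether the configuration at this saturated ring carbon has any effect on inhibition in this assay.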